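The source may report more compounds than this note shows. Statements on the series, on what has been measured and on what is new or still open speak of the compounds shown alone.

Measured compounds:
- Compound 1, `Cc1cccc(Nc2cc(Cl)nc(SC(C(=O)O)c3ccccc3)n2)c1C`, in an assay for inhibition of Polyunsaturated fatty acid 5-lipoxygenase (Homo sapiens), tested at 1 uM (a lower number here means a stronger effect, a higher number a weaker effect of the compound at the concentration tested), compound 1 is reported as "not active" (no number reported).
- Compound 2, `CCOC(=O)C(C)Sc1nc(Cl)cc(Nc2cccc(C)c2C)n1`, in this assay compound 2 is reported as "not active" (no number reported).
- Compound 3, `CCOC(=O)CSc1nc(Cl)cc(Nc2ccc3ncccc3c2)n1`, in this assay compound 3 gives 86.3%.

Compound 2 stands without a number: in this assay it is recorded only as not active, and compound 1 shares that outcome, so no figure places compound 2 against compound 3. Compound 3 is the only one of the three with a measured read-out, and its value leaves most of the enzyme activity in place, a weak effect. Going by the values given here, no step between two measured compounds is available here.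

Compound 4, `CCCCCCC(Sc1nc(Cl)cc(Nc2cccc(C)c2C)n1)C(=O)OCC`, is yet to be tested in this assay. It differs from compound 2 by pentyl in place of hydrogen on a saturated chain carbon, two bonds along the chain from a carbonyl carbon and a sulfur. Among the compounds with values here, with compound 2 inactive and the nearest measured analogue, compound 3, showing only a small effect, the account expects no step in this assay that clearly exceeds the scatter; compound 4 is expected to remain weak, with a fair chance that the assay again reports only "not active" rather than a number. The estimate for compound 4 in this assay is 90%, expected to fall between 70% and 100%.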

Compound 4, a percentage reported as activity, at one concentration (the size of the read-out at that concentration, not a potency): 84.9%
Estimate against measurement, compound 4: 5.1 percentage points above; low and high end bracket the measured number.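

Going by these compounds alone, compound 2 is recorded only as not active while compound 4 carries a number, so no step between the two can be read. The compounds shown leave open how far pentyl in place of hydrogen on that chain carbon shifts the read-out, if at all. Nothing available here bears on the result of compound 4.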